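Fluorine for chlorine on the benzyl group of a cytotoxic thiazolidinedione

A few compounds are considered here, and "the series" means these few. Any claim that something is new, unique, unknown or untested is made for them only; others in the source may bear on it.

Compound 2 `Nc1cccc(/C=C2\SC(=O)N(Cc3cccc(Cl)c3)C2=O)c1` gives 195000 nM in a functional assay on CCRF-CEM cells (Homo sapiens) for cytotoxicity, read by cell counting, with a stated time of 3 days (on this read-out lower numbers stand for stronger inhibition and higher numbers for weaker inhibition), while compound 1 `Nc1cccc(/C=C2\SC(=O)N(Cc3ccc(F)cc3)C2=O)c1` gives 87000 nM. The change between them is 4-fluorophenyl in place of 3-chlorophenyl on a saturated chain carbon bound to an amide-type nitrogen in a ring, and it made a step of a 2.2-fold lower number from compound 2 to compound 1 (0.35 log units; beyond the scatter). Compound 3 `C=C(Br)C(=O)Nc1cccc(/C=C2\SC(=O)N(Cc3cccc(Cl)c3)C2=O)c1` differs from compound 2 by (1-bromoethenyl)carbonyl in place of hydrogen on a nitrogen on an aromatic ring, which brought a step of a 140-fold lower number from compound 2 to compound 3 (2.14 log units; beyond the scatter); in this assay compound 3 gives 1400 nM. Compound 4 `C=C(Br)C(=O)Nc1cccc(/C=C2\SC(=O)N(Cc3ccc(F)cc3)C2=O)c1` has not been measured; it differs from compound 3 by 4-fluorophenyl in place of 3-chlorophenyl on a saturated chain carbon bound to an amide-type nitrogen in a ring, the same change that separates compound 2 from compound 1, since the place is identical in both pairs. Resting on that earlier step of a 2.2-fold lower number from compound 2 to compound 1 (0.35 log units; beyond the scatter), the step from compound 3 to compound 4 is expected to be a 2.0-fold lower number from compound 3 to compound 4 (0.30 log units; within the scatter). Compound 4 is therefore estimated to give 700 nM in this assay, most likely between 250 nM and 2000 nM.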

Compound 4, half-maximal inhibitory concentration: 680 nM
For compound 4 the middle estimate is 1.0-fold (0.01 log units) above the measured one, within the range that was stated.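

In this assay, the change from 3-chlorobenzyl to 4-fluorobenzyl gave a 2.1-fold lower number from compound 3 to compound 4 (0.31 log units; beyond the scatter), matching the step on the core without the (1-bromoethenyl)carbonyl group: the same change on two cores in this assay, a 2.2-fold lower number (0.35 log units; beyond the scatter) from compound 2 to compound 1 and a 2.1-fold lower number (0.31 log units; beyond the scatter) from compound 3 to compound 4, 1.1-fold (0.04 log units) apart, within the scatter of two such steps. The (1-bromoethenyl)carbonyl change in turn gave a 130-fold lower number from compound 1 to compound 4 (2.11 log units; beyond the scatter) with the 4-fluorophenyl group in place, again matching its step with 3-chlorophenyl: the same change on two cores in this assay, a 140-fold lower number (2.14 log units; beyond the scatter) from compound 2 to compound 3 and a 130-fold lower number (2.11 log units; beyond the scatter) from compound 1 to compound 4, 1.1-fold (0.04 log units) apart, within the scatter of two such steps. Each change therefore carried over between these two cores at nearly the same size, but this covers only four compounds in one read-out and does not show that it would hold on any other core.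

The compounds shown leave open what a plain benzyl group would give at this place, and they do not separate the identity of the halogen from where it sits on the ring. Also open, going by these compounds, is whether an acetyl group on the aromatic nitrogen would give a step of similar size.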